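This account rests on a few compounds, and the source may have more. Where it says the series, first, only, none or still open, it means among the compounds named here.

Working notes on the series. Of the compounds shown here, three have been read in a functional assay on the whole organism (strain Wistar Albino) for inhibition, with Rattus norvegicus as the target, read by paw edema, with a stated time of 4 h, at a dose of 20 mg/kg; on this read-out lower numbers stand for less inhibition and higher numbers for more inhibition at the one dose given (going by the name of the read-out). Compound 1 `Cc1occc1-c1nnc2sc(-c3cc(O)nc(O)c3)nn12` gives 21.7% in this assay. Compound 2 `COc1ccc(Cc2nnc3n2NC(c2ccco2)S3)cc1OC` gives 24.6%. Compound 3 `Cc1occc1-c1nnc2n1NC(c1ccco1)S2` gives 25.9%, the highest of the three numbers shown, but compound 2 and compound 1 each lie within the scatter of it, so the three stand together and no ranking can be drawn. Going by the values given here, no two measured compounds differ in a single place, so no measured step exists to guide an expectation. Compound 4 `Cc1occc1-c1nnc2n1NC(c1ccc([N+](=O)[O-])o1)S2` differs from compound 3 by nitro in place of hydrogen on an aromatic carbon. Among the compounds with values here, with no comparable step known, the change from compound 3 to compound 4 is expected to give a number 0.1 percentage points higher from compound 3 to compound 4 (within the scatter), nothing beyond the scatter in either direction. Compound 4 is accordingly estimated at 26%, within 15% to 37%.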

Compound 4, a percentage reported as inhibition, in the whole organism at one dose (the size of the read-out at that dose, not a potency): 24.9%
Beside the measured number, compound 4's estimate is 1.1 percentage points above it, within the range that was stated.
By their numbers in this assay, from the lowest: compounds 1, 2, 4 and 3 (each within the scatter of the next).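

Going by these compounds alone, the first single-place step places nitro in place of hydrogen on an aromatic carbon next to the ring oxygen, and it gives a number 1 percentage points lower from compound 3 to compound 4 (within the scatter) in this assay at the one dose. This position therefore accepts nitro with no change beyond the scatter. No separate measurement bears on this result.

Going by these compounds, whether an amine or a carboxylic acid at this same position would move the number beyond the scatter stays open. Also open, on these data alone, is whether nitro would behave alike at another dose.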